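The source may hold more compounds than are shown below. What is called first, only, known or untested is meant among the compounds shown, and "the series" means these compounds.

Of the compounds shown here, three sharing one core have been measured in an ADME assay on microsomes from liver (Homo sapiens) for metabolic stability, with a stated time of 10 min; on this read-out higher numbers stand for a more stable compound and lower numbers for a less stable compound. Compound 1 `Cc1ccccc1S(=O)(=O)NC(=O)c1ccc(Nc2nc(NC3(c4ccc(Cl)cc4)CC3)nc(OCC(F)(F)F)n2)cc1` gives 100%. Compound 2 `CC(C)S(=O)(=O)NC(=O)c1ccc(Nc2nc(NC3(c4ccc(Cl)cc4)CC3)nc(OCC(F)(F)F)n2)cc1` gives 100%, and compound 3 `O=C(NS(=O)(=O)c1ccc(F)cc1)c1ccc(Nc2nc(NC3(c4ccc(Cl)cc4)CC3)nc(OCC(F)(F)F)n2)cc1` gives 100%. These three differ only in the group on the sulfonyl sulfur, and none of the exchanges moved the read-out: no change at the digits printed from compound 1 to compound 2 (within the scatter), no change at the digits printed from compound 1 to compound 3 (within the scatter) and no change at the digits printed from compound 2 to compound 3 (within the scatter). Compound 3 therefore stands level with compounds 1 and 2 on this read-out, with every value at the top of the scale. Compound 4 `CS(=O)(=O)NC(=O)c1ccc(Nc2nc(NC3(c4ccc(Cl)cc4)CC3)nc(OCC(F)(F)F)n2)cc1` is the next step from compound 3, differing by methyl in place of 4-fluorophenyl on a sulfonyl sulfur. All three measured steps bear on it, since each also swaps one group on a sulfonyl sulfur, and each was flat within the scatter. Among the measured compounds shown here, the expected step is no change at the digits printed from compound 3 to compound 4 (within the scatter), nothing beyond the scatter, although none of the measured compounds carries a group as small as methyl on a sulfonyl sulfur. Compound 4 is accordingly estimated at 100%, expected to lie between 90% and 100%.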

Compound 4, percent of the compound remaining: 100%
Compound 4: middle estimate and measured number agree at the digits printed; low and high end bracket the measured number.
By their numbers in this assay, from the lowest: compounds 1, 2, 3 and 4 (each within the scatter of the next).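

In this assay, going down to methyl, the group with the fewest heavy atoms in this set, still leaves the read-out flat (no change at the digits printed from compound 3 to compound 4 (within the scatter); no change at the digits printed from compound 2 to compound 4 (within the scatter); no change at the digits printed from compound 1 to compound 4 (within the scatter)). The earlier compounds shown here showed this only for groups carrying more atoms, so the flat result now holds for a single carbon with no ring as well as for 4-fluorophenyl, isopropyl and 2-methylphenyl. No measurement available here accounts for this flatness.

All four compounds sit at the top of the scale, so any difference in stability among them remains hidden on this read-out. Also open, going by these compounds, is whether a longer chain, an amine or a carboxylic acid on the sulfonyl sulfur, or any exchange elsewhere on the shared core, would bring the value down.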